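A few compounds are considered here, and "the series" means these few. Any claim that something is new, unique, unknown or untested is made for them only; others in the source may bear on it.

Compound 1 `COc1cc(Cl)c(C(=O)N=C(N)N)cc1S(C)(=O)=O` is the starting point of this small set. In a functional assay for inhibition of sodium/hydrogen exchanger (Oryctolagus cuniculus) (a higher number here means a weaker inhibitor, a lower number a stronger inhibitor), compound 1 gives 40 nM. Compound 2 `CS(=O)(=O)c1cc(C(=O)N=C(N)N)c(Cl)cc1Oc1cccnc1` differs from compound 1 by a single change, (pyridin-3-yl in place of methyl on an oxygen on an aromatic ring). In this assay compound 2 gives 52 nM, so the step is a 1.3-fold higher number from compound 1 to compound 2 (0.11 log units; within the scatter). Compound 3 `COc1ccc(C(=O)N=C(N)N)cc1S(C)(=O)=O` is built on a different core; the difference between the two cores is hydrogen in place of chloro on an aromatic carbon. In this assay compound 3 gives 270 nM, and the step is a 6.8-fold higher number from compound 1 to compound 3 (0.83 log units; beyond the scatter), which makes compound 3 the weakest inhibitor of the three measured compounds. Compound 4 `CS(=O)(=O)c1cc(C(=O)N=C(N)N)ccc1Oc1cccnc1` has not yet been measured. For the measured compounds named here, it differs from compound 3 by pyridin-3-yl in place of methyl on an oxygen on an aromatic ring, the same change in the same place as the one separating compound 1 from compound 2. Because that earlier change gave a 1.3-fold higher number from compound 1 to compound 2 (0.11 log units; within the scatter), the step is expected to be of similar small size, a 1.2-fold higher number from compound 3 to compound 4 (0.09 log units; within the scatter), and so to stay within the usual scatter. For compound 4 the expected value in this assay is therefore 330 nM, with a range from 150 nM to 700 nM.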

Compound 4, half-maximal inhibitory concentration: 76 nM
Compound 4: middle estimate off by 4.3-fold (0.64 log units), on the high side, and the stated range ends above it.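

In this assay, the change from methoxy to (pyridin-3-yl)oxy gave a 3.6-fold lower number from compound 3 to compound 4 (0.55 log units; beyond the scatter), so the small step seen on the core of compound 1 did not carry over to the core of compound 3: the same change on two cores in this assay, a 1.3-fold higher number (0.11 log units; within the scatter) from compound 1 to compound 2 and a 3.6-fold lower number (0.55 log units; beyond the scatter) from compound 3 to compound 4, 4.6-fold (0.66 log units) apart, beyond the scatter of two such steps. Read the other way, hydrogen in place of chloro gives a 1.5-fold higher number from compound 2 to compound 4 (0.16 log units; within the scatter) when the oxygen carries pyridin-3-yl, a much smaller step than the one seen when it carries methyl: the same change on two cores in this assay, a 6.8-fold higher number (0.83 log units; beyond the scatter) from compound 1 to compound 3 and a 1.5-fold higher number (0.16 log units; within the scatter) from compound 2 to compound 4, 4.6-fold (0.66 log units) apart, beyond the scatter of two such steps. These four compounds therefore show that the two changes do not act independently here, so the size of a step on one core is a poor guide to its size on the other, but they do not show why, and they rest on a single pair of cores.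

On these data alone, it remains open whether another group on the oxygen, such as phenyl or an ethyl chain, would depend on the chloro in the same way. As far as these compounds go, it is also open whether fluoro or methyl in place of chloro would produce a similar gap between the steps.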